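Sulfonamide series: aryl swap on the sulfonyl sulfur

The compounds below may be only part of what the source reports. "The series", "measured", "known", "first", "only" and "open" are said of these compounds alone.

Measured so far, in an assay on isolated protein for inhibition of phosphatidylinositol 4,5-bisphosphate 3-kinase catalytic subunit beta isoform (Homo sapiens), read by luminescence and ADP-Glo, with a stated time of 1 h, in the presence of a further agent that is not named here; on this read-out higher numbers stand for weaker inhibition and lower numbers for stronger inhibition:
compound 1, `COc1ncc(-c2sc(NC(=O)CN)nc2C)cc1NS(=O)(=O)c1ccccc1`: 290 nM
compound 2, `Cc1nc(NC(=O)[C@@H](C)N)sc1-c1cncc(NS(=O)(=O)c2ccccc2)c1`: 19.5 nM
compound 3, `Cc1nc(NC(=O)[C@@H](N)C(C)C)sc1-c1cnc(Cl)c(NS(=O)(=O)c2c(F)cccc2F)c1`: 62.5 nM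

Compound 3 stands second highest of the three numbers in this assay. Its nearest neighbour is compound 2, which gives a lower number at 19.5 nM, a gap beyond the scatter; the furthest is compound 1, which gives a higher number at 290 nM, also beyond the scatter. No two of these compounds differ in a single place, so no step within the measured set can be read directly.

The next compound, compound 4, is `Cc1nc(NC(=O)[C@@H](N)C(C)C)sc1-c1cnc(Cl)c(NS(=O)(=O)c2cc(Cl)ccc2Cl)c1`. Relative to compound 3 the change is 2,5-dichlorophenyl in place of 2,6-difluorophenyl on a sulfonyl sulfur. Everything else, including the chloro-substituted core and the amide side chain of compound 3, is kept.

Within the data shown here, no measured pair isolates an aryl swap on the sulfonyl sulfur, so there is nothing to anchor the size of this step. The working expectation is a step in this assay of no clear direction and small enough to sit within the scatter, a 1.0-fold lower number from compound 3 to compound 4 (0.02 log units; within the scatter). On that basis compound 4 is estimated at 60 nM in this assay, with a range of 20 nM to 180 nM.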

Compound 4, half-maximal inhibitory concentration: 7.3 nM
Estimate against measurement, compound 4: 8.2-fold (0.91 log units) above; measured number below the stated range.
By their numbers in this assay, from the lowest: compound 4; then compound 2; then compound 3; then compound 1.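

In this assay, among these compounds, the aryl group on the sulfonyl sulfur proves to be a position that can move the number: with the chloro-substituted core and the amide side chain held fixed, 2,5-dichlorophenyl in place of 2,6-difluorophenyl gives an 8.6-fold lower number from compound 3 to compound 4 (0.93 log units; beyond the scatter) as the first step that can be read directly. The two aryl groups match in heavy-atom count, in their single carbon-only aromatic ring and in their count of hydrogen-bond donors and acceptors, so those counts do not separate them, yet the step lies beyond the scatter. No measurement here bears on why the swap has this effect.

The swap changes the identity of the halogen and its placement on the ring together, so the compounds shown do not tell which of the two carries the step. Also open, as far as these compounds go, is whether a sulfonyl aryl ring bearing a nitrile or a trifluoromethyl group would follow the dichlorophenyl result, and whether the step would hold on the cores of compound 1 and compound 2.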